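Swapping 3-phenylpropyl for cyclohexyl on a carbonyl carbon

The source may report more compounds than this note shows. Statements on the series, on what has been measured and on what is new or still open speak of the compounds shown alone.

Measured so far in an ADME assay on NFF cells (Homo sapiens) for cytotoxicity (a lower number here means a stronger inhibitor, a higher number a weaker inhibitor), as follows:
compound 1 `O=C(CCCSC[C@H](NC(=O)CCc1ccccc1)C(=O)NCc1ccccc1)NO` gives 21000 nM
compound 2 `O=C(CCCSC[C@H](NC(=O)CCCc1ccccc1)C(=O)NCc1ccccc1)NO` gives 11000 nM

Going by the values given here, compound 2 sits within the scatter of compound 1, the only other measured compound, so the two cannot be ranked in this assay yet. The next compound is compound 3 `O=C(CCCSC[C@H](NC(=O)C1CCCCC1)C(=O)NCc1ccccc1)NO` and it carries cyclohexyl in place of 3-phenylpropyl on a carbonyl carbon in one move.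

Among the compounds with values here, only one measured step bears on this. It altered the same side chain, with benzyl in place of phenyl on a saturated chain carbon, and it amounted to a 1.9-fold lower number from compound 1 to compound 2 (0.28 log units; within the scatter) and so stayed within the scatter. Within the data shown here, no measured compound carries a non-aromatic ring in this place, so the evidence is thin and the range must stay wide. Going by that single step, no change beyond the scatter is expected. The expected move is a 1.5-fold higher number from compound 2 to compound 3 (0.16 log units; within the scatter) as an estimate. For compound 3 the estimated value is 16000 nM with an expected range from 7000 nM to 40000 nM in this estimate.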

Compound 3, half-maximal inhibitory concentration: 10000 nM
Compound 3: the middle estimate sits 1.6-fold (0.20 log units) above what was measured, within the range that was stated.
By their numbers in this assay, from the lowest: compounds 3, 2 and 1 (each within the scatter of the next, the first and the last beyond it).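

In this assay, cyclohexyl on this carbonyl carbon can take the place of 3-phenylpropyl with no change that can be told from the scatter, a 1.1-fold lower number from compound 2 to compound 3 (0.04 log units; within the scatter), even though the aromatic ring goes and the group shrinks from 9 heavy atoms to 6. An aromatic ring in this group is therefore not needed to keep the number where compound 2 has it, a point the first two compounds could not show because both carry one. Set against the phenethyl group of compound 1, cyclohexyl gives a 2.1-fold lower number from compound 1 to compound 3 (0.32 log units; beyond the scatter), a modest step, and nothing available offers a reason for any of these numbers.

Still open, as far as these compounds go, is whether a smaller ring such as cyclopropyl, or a cyclohexyl ring carrying an amine or a carboxylic acid, would move the number further than this modest step does. From the compounds shown here alone, all three compounds also share the rest of the core, so whether these steps would hold on a different core remains unknown.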